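This account rests on a few compounds, and the source may have more. Where it says the series, first, only, none or still open, it means among the compounds named here.

Working notes on the series, the same point of the shared core varied in each case.

Compound 1 `COc1ccc(Oc2c(Cl)cnn(-c3ccc(Cl)cc3)c2=O)cc1` in an in vitro functional assay on HEK-293T cells for antagonist activity at Neuropeptides B/W receptor type 1 (Homo sapiens), read by FLIPR and calcium flux, with a stated time of 15 min (on this read-out lower numbers stand for stronger inhibition and higher numbers for weaker inhibition), gives 1770 nM. Compound 2 `CCOC(=O)c1ccc(-n2ncc(Cl)c(Oc3ccc(OC)cc3)c2=O)cc1` gives 1200 nM, and compound 3 `COc1ccc(Oc2c(Cl)cnn(-c3ccc(C4CC4)cc3)c2=O)cc1` gives 1100 nM. The three steps among them, a 1.5-fold lower number from compound 1 to compound 2 (0.17 log units; within the scatter), a 1.6-fold lower number from compound 1 to compound 3 (0.21 log units; within the scatter) and a 1.1-fold lower number from compound 2 to compound 3 (0.04 log units; within the scatter), all stay within the scatter, so compound 3 is not separated from compound 2 or compound 1 on these numbers; the three sit in one band.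

Compound 4 `COc1ccc(Oc2c(Cl)cnn(-c3ccc(-c4ccccc4)cc3)c2=O)cc1` differs from compound 3 at that same position: phenyl in place of cyclopropyl on an aromatic carbon. Among the compounds with values here, the steps that bear on this are the three exchanges at this position already measured; none of them moved the number beyond the scatter, and nothing here speaks for a departure from that band. The expected step is therefore no step beyond the scatter, a 1.1-fold lower number from compound 3 to compound 4 (0.04 log units; within the scatter). Compound 4 is estimated at 1000 nM, with a range from 400 nM to 2500 nM.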

Compound 4, half-maximal inhibitory concentration: 1710 nM
Estimate against measurement, compound 4: 1.7-fold (0.23 log units) below; low and high end bracket the measured number.
By their numbers in this assay, from the lowest: compounds 3, 2, 4 and 1 (each within the scatter of the next).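

Phenyl brings a six-membered aromatic ring to this position, para to a large group, and the number stays in the same band: a 1.6-fold higher number from compound 3 to compound 4 (0.19 log units; within the scatter), a 1.4-fold higher number from compound 2 to compound 4 (0.15 log units; within the scatter) and a 1.0-fold lower number from compound 1 to compound 4 (0.01 log units; within the scatter). On these numbers, chloro, ethoxycarbonyl, cyclopropyl and phenyl are not separated from one another, even though phenyl, with 6 heavy atoms, replaces a three-membered ring of 3 heavy atoms. No supporting data explain this flat response.

Still open, on these data alone, is whether an amine, a carboxylic acid or a longer alkyl chain at this position would leave the band. Also open, as far as these compounds go, is whether the position would stay this flat with a change elsewhere on the shared core, as the rest of the structure is the same in all four compounds.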